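Swapping methyl for fluoro on the benzyl of compound 3

A few compounds are considered here, and "the series" means these few. Any claim that something is new, unique, unknown or untested is made for them only; others in the source may bear on it.

Of the compounds shown here, three sharing one core have been tested in an assay on CHO cells for displacement of a labelled ligand from adenosine receptor A3 (Homo sapiens); a lower number here means a stronger inhibitor, a higher number a weaker inhibitor. Compound 1 `O=C(Nc1ncc(C(=O)O)c2nc(-c3ccco3)nn12)NC1CCCCC1` gives 59400 nM. Compound 3 `Cc1ccc(CNc2ncc(C(=O)O)c3nc(-c4ccco4)nn23)cc1` gives 751 nM, and compound 2 `CCOC(=O)c1cnc(NCc2ccc(F)cc2)n2nc(-c3ccco3)nc12` gives 46.3 nM. Compound 3 therefore sits in the middle of the three measured numbers: above compound 2 and well below compound 1.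

Within the data shown here, the one measured step within this set, a 79-fold lower number from compound 1 to compound 3 (1.90 log units; beyond the scatter), replaces a cyclohexylcarbamoyl on the ring nitrogen with a 4-methylbenzyl, a change of a different kind from the one considered here.

Compound 4 `O=C(O)c1cnc(NCc2ccc(F)cc2)n2nc(-c3ccco3)nc12` differs from compound 3 only at one place on the six-membered carbon ring: fluoro in place of methyl on an aromatic carbon. Among the measured compounds shown here, no measured step in this set exchanges a methyl for a fluoro, so there is nothing to lean on directly. Compound 2 carries the same 4-fluorobenzyl as compound 4 but an ethyl ester rather than an acid, and its value shows that this benzyl is compatible with strong binding. Swapping one small group for another of the same size at the far end of the benzyl is expected to move the number little.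

The step from compound 3 to compound 4 is therefore estimated as a 1.3-fold lower number from compound 3 to compound 4 (0.10 log units; within the scatter), within the scatter. Compound 4 is expected to give about 600 nM, most likely between 200 nM and 2000 nM.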

Compound 4, inhibition constant: 14000 nM
For compound 4 the middle estimate is 23-fold (1.37 log units) below the measured one, outside the stated range (above it).
By their numbers in this assay, from the lowest: compound 2; then compound 3; then compound 4; then compound 1.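

In this assay, the carbon para to a large group on the benzyl turns out to be far from indifferent: exchanging one heavy atom, methyl for fluoro, gives a 19-fold higher number from compound 3 to compound 4 (1.27 log units; beyond the scatter) and so moves the number well beyond the scatter. The 4-fluorobenzyl does not secure strong binding by itself, since a 300-fold higher number from compound 2 to compound 4 (2.48 log units; beyond the scatter) when the ethyl is removed from the ester, and replacing cyclohexylcarbamoyl on the acid gives only a 4.2-fold lower number from compound 1 to compound 4 (0.63 log units; beyond the scatter) with this benzyl, against a 79-fold lower number from compound 1 to compound 3 (1.90 log units; beyond the scatter) with the 4-methylbenzyl. Nothing available here explains why methyl and fluoro differ so much at this carbon.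

The compounds shown leave open whether methyl would also beat fluoro in the ethyl ester series, since the ester carrying the 4-methylbenzyl is not among them. They also leave open how chloro, methoxy or a plain hydrogen at the same carbon would compare, and so whether methyl is unusually favourable or fluoro unusually poor on the acid.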